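Three Measured Compounds and a Ring Nitrogen Entering

The source may report more compounds than this note shows. Statements on the series, on what has been measured and on what is new or still open speak of the compounds shown alone.

Of the compounds shown here, three built on a shared core have been tested in a functional assay on HEK293 cells with D(4) dopamine receptor (Homo sapiens) as the target, read by FLIPR; a lower number here means a smaller maximal response, a higher number a larger maximal response. Compound 1 `Cc1ccccc1/C(CCN1CCN(c2ccccn2)CC1)=N/O` gives 82%. Compound 2 `CCO/N=C(\CCN1CCN(c2ccccc2C#N)CC1)c1ccccc1` gives 82%, and compound 3 `CO/N=C(\CCN1CCN(c2ccccc2OC(C)C)CC1)c1ccc(F)cc1` gives 46%.

Compound 2 stands level with compound 1 at the digits shown, the two together the highest of the three numbers; the difference between compound 2 and compound 1 lies within the scatter, so no order between them can be claimed. Compound 3 sits a long way lower than compound 2, a gap that lies beyond the scatter.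

Compound 4 `CCO/N=C(\CCN1CCN(c2ncccc2C#N)CC1)c1ccccc1` has not yet been measured. It differs from compound 2 in one place: 3-cyanopyridin-2-yl in place of 2-cyanophenyl on an amine nitrogen in a ring. Going by the values given here, no pair of measured compounds differs in only this way, so there is no measured step to lean on.

With nothing measured for such a change, the expectation is a step in this assay that is small, at most a modest drop, and most likely within the scatter. Compound 4 is therefore estimated at 76%, with a range from 52% to 95%. This estimate means a step of a number 6 percentage points lower from compound 2 to compound 4 (within the scatter), expected to stay within the usual scatter.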

Compound 4, largest response reached (reported as efficacy), in percent of the reference or control that the assay uses: 64%
Beside the measured number, compound 4's estimate is 12 percentage points above it, and the stated range covers the measured number.
By their numbers in this assay, from the lowest: compound 3; then compound 4; then compounds 1 and 2 (each within the scatter of the next).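

In this assay, going by these compounds alone, putting 3-cyanopyridin-2-yl in place of 2-cyanophenyl on an amine nitrogen in a ring gives a number 18 percentage points lower from compound 2 to compound 4 (beyond the scatter), the first change in one place that can be read in this set. The two groups have the same number of heavy atoms and both carry a nitrile; the computed difference is one ring carbon exchanged for a ring nitrogen, which raises the count of hydrogen-bond acceptors, so this position is sensitive to a change as small as one atom within the aromatic ring. Nothing measured here bears on why the response falls.

This single pair cannot show whether the same exchange would lower the response with another group in place of the nitrile, such as a chlorine atom or a methoxy group. It also leaves open whether a ring nitrogen has a similar effect when the ethyl group on the oxime oxygen is replaced by a methyl group or a longer chain.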